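Moving the pyridine nitrogen on a chemokine receptor antagonist

A few compounds are considered here, and "the series" means these few. Any claim that something is new, unique, unknown or untested is made for them only; others in the source may bear on it.

Of the compounds shown here, two sharing one core have been measured. In a functional assay on cells for antagonist activity at C-X-C chemokine receptor type 4 (Homo sapiens), read by fluorescence and calcium flux, with stated times of 25 min and 90 s (a lower number here means a stronger inhibitor, a higher number a weaker inhibitor), compound 1 `c1cncc(CNCCCCN(C[C@H]2Cc3ccccc3CN2)[C@H]2CCCc3cccnc32)c1` gives 15.3 nM, while compound 2 `C(=C/CN(C[C@H]1Cc2ccccc2CN1)[C@H]1CCCc2cccnc21)\CNCc1ccccn1` gives 58.3 nM, the higher of the two numbers; the step of a 3.8-fold higher number from compound 1 to compound 2 (0.58 log units; beyond the scatter) exchanges one whole side group for another. Compound 3 `C(=C/CN(C[C@H]1Cc2ccccc2CN1)[C@H]1CCCc2cccnc21)\CNCc1cccnc1` differs from compound 2 only in pyridin-3-yl in place of pyridin-2-yl on a saturated chain carbon bound to an amine nitrogen, so it carries the same pyridine as compound 1 but the unsaturated chain of compound 2. Within the data shown here, the single measured step changes chain and pyridine together, so the share belonging to the pyridine alone cannot be separated from it; it sets only a rough ceiling on what the ring exchange might do. A small gain in this assay, or no change beyond the scatter, is therefore expected, as a 1.7-fold lower number from compound 2 to compound 3 (0.22 log units; within the scatter). Compound 3 is estimated at 35 nM, within a range from 12 nM to 90 nM.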

Compound 3, half-maximal inhibitory concentration in the C-X-C chemokine receptor type 4 assay: 92.8 nM
For compound 3 the middle estimate is 2.7-fold (0.42 log units) below the measured one; the whole stated range lies below it.
By their numbers in the C-X-C chemokine receptor type 4 assay, from the lowest: compound 1; then compounds 2 and 3 (each within the scatter of the next).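

In the C-X-C chemokine receptor type 4 assay, exchanging pyridin-2-yl for pyridin-3-yl on the unsaturated chain gives a 1.6-fold higher number from compound 2 to compound 3 (0.20 log units; within the scatter), and compound 3 gives 92.8 nM, so at this position the two pyridines cannot be told apart in this assay. With the pyridin-3-yl group held constant, the comparison of the saturated chain with the unsaturated one gives a 6.1-fold higher number from compound 1 to compound 3 (0.78 log units; beyond the scatter), which ties the difference beyond the scatter to the chain rather than to the place of the ring nitrogen. No supporting measurement explains why the chain matters here.

In a physicochemical assay for permeability, using PAMPA, with a stated time of 4 h, at pH 5.5, tested at 100 uM (on this read-out lower numbers stand for lower permeability and higher numbers for higher permeability), compound 2 gives 18 nm/s, but compound 3 gives "not determined" (no result reported), so the pyridine exchange cannot be read there. Still open, on these data alone, is how a pyridin-4-yl group or a phenyl ring would fare on either chain, and whether a longer chain would change the picture.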